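Aryl Amide Variation on a Shared Core: Compound 4 Expected

A few compounds are considered here, and "the series" means these few. Any claim that something is new, unique, unknown or untested is made for them only; others in the source may bear on it.

Compound 1 `COc1cccc(NC(=O)CSc2nc(Nc3ccccc3)c3ccccc3n2)c1` gives 21700 nM in a functional assay on MDA-MB-231 cells (Homo sapiens) for inhibition, read by MTT assay, with a stated time of 72 h; on this read-out lower numbers stand for stronger inhibition and higher numbers for weaker inhibition.
Compound 2 `O=C(CSc1nc(Nc2ccccc2)c2ccccc2n1)Nc1ccc(Br)cc1` gives 11500 nM in this assay.
Compound 3 `O=C(CSc1nc(Nc2ccccc2)c2ccccc2n1)Nc1ccc(C(F)(F)F)cc1` gives 11100 nM in this assay.

Compound 3 holds the lowest of the three numbers, yet both others lie within the scatter of it: a 2.0-fold lower number from compound 1 to compound 3 (0.29 log units; within the scatter) and a 1.0-fold lower number from compound 2 to compound 3 (0.02 log units; within the scatter). Compound 4 `O=C(CSc1nc(Nc2ccccc2)c2ccccc2n1)Nc1ccc(Cl)cc1Cl` is the next step from compound 3: 2,4-dichlorophenyl in place of 4-(trifluoromethyl)phenyl on an amide-type nitrogen. The measured steps that bear on this are those that exchanged the aryl group on the same amide-type nitrogen, a 1.9-fold lower number from compound 1 to compound 2 (0.28 log units; within the scatter) and a 1.0-fold lower number from compound 2 to compound 3 (0.02 log units; within the scatter), none reaching beyond the scatter. A further exchange of the phenyl group on that nitrogen is therefore expected to give no step beyond the scatter in this assay, so compound 4 is estimated at 10500 nM with a range of 4500 nM to 25000 nM. This expectation means a 1.1-fold lower number from compound 3 to compound 4 (0.02 log units; within the scatter).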

Compound 4, half-maximal inhibitory concentration: 19400 nM
For compound 4 the middle estimate is 1.8-fold (0.27 log units) below the measured one; the range from low to high includes it.
By their numbers in this assay, from the lowest: compounds 3, 2, 4 and 1 (each within the scatter of the next).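

In this assay, 2,4-dichlorophenyl on the amide-type nitrogen gives a 1.7-fold higher number from compound 3 to compound 4 (0.24 log units; within the scatter), a 1.7-fold higher number from compound 2 to compound 4 (0.23 log units; within the scatter) and a 1.1-fold lower number from compound 1 to compound 4 (0.05 log units; within the scatter). Even with two chlorine atoms on the ring, then, no exchange of the aryl group at this place reaches beyond the scatter, and the four aryl groups cannot be told apart by this read-out. Nothing available explains this result.

The compounds shown leave open whether an aryl group bearing an amine or a carboxylic acid, or a longer alkyl chain in place of the aryl group, would give a step beyond the scatter.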